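Alkyl-to-arylalkyl exchange in a microsomal inhibition series

A few compounds are considered here, and "the series" means these few. Any claim that something is new, unique, unknown or untested is made for them only; others in the source may bear on it.

Measured so far:
compound 1 `CCCCCCc1nc2ccccc2[nH]1`: 32400 nM
compound 2 `CC(=O)Nc1ccc2[nH]c(C)nc2c1`: 1260000 nM
compound 3 `CCc1nc2cc(C)ccc2[nH]1`: 269000 nM

In an ADME assay on microsomes from liver for inhibition of cytochrome P450 2B1 (Rattus norvegicus) (a higher number here means a weaker inhibitor, a lower number a stronger inhibitor), compound 1 gives 32400 nM, the lowest of the three numbers. Compound 3 gives 269000 nM, and compound 2 gives 1260000 nM; both gaps to compound 1 lie beyond the scatter, so compound 1 is the strongest inhibitor of the three in this assay.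

The next compound, compound 4 `c1ccc(CCCc2nc3ccccc3[nH]2)cc1`, differs from compound 1 in one place: phenyl in place of propyl on a saturated chain carbon, three bonds along the chain from an aromatic carbon. Among the measured compounds shown here, no measured pair shows such an exchange, so there is no step to lean on. The chain retains the same point of attachment to the core of compound 1, and the change is expected to move the number little, if at all, beyond the scatter. The step is expected to be a 1.3-fold lower number from compound 1 to compound 4 (0.11 log units; within the scatter). Compound 4 is estimated at 25000 nM, with a range of 6000 nM to 100000 nM.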

Compound 4, half-maximal inhibitory concentration: 19100 nM
Compound 4: middle estimate off by 1.3-fold (0.12 log units), on the high side; the range from low to high includes it.
By their numbers in this assay, from the lowest: compounds 4 and 1 (each within the scatter of the next); then compound 3; then compound 2.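

In this assay, the step of a 1.7-fold lower number from compound 1 to compound 4 (0.23 log units; within the scatter) shows that a saturated chain carbon, three bonds along the chain from an aromatic carbon, can carry phenyl in place of propyl with no change beyond the scatter. Compounds 1 and 4 therefore stand level, and the six-membered aromatic ring is tolerated at this place. Nothing available explains this result.

This rests on a single pair, so it sets no trend. Open, as far as these compounds go, is whether an amine or a carboxylic acid on the phenyl ring, or a longer chain carrying it, would hold the number at this level.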